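This account rests on a few compounds, and the source may have more. Where it says the series, first, only, none or still open, it means among the compounds named here.

Working notes on the series. Among the measured compounds shown here, in a functional assay for agonist activity at G protein-coupled receptor 88 (Homo sapiens), read by HTRF and cAMP accumulation (on this read-out lower numbers stand for an effect already at smaller amounts and higher numbers for an effect only at larger amounts of compound), compound 2 `CC[C@H](C)[C@H](N)CN(C(=O)[C@@H]1C[C@H]1c1cccc(F)c1)c1ccc(-c2ccccc2)cc1` stands lowest of the two numbers so far at 560 nM, while compound 1 `CC[C@H](C)[C@H](N)CN(C(=O)[C@@H]1C[C@H]1c1ccc(Cl)cc1)c1ccc(-c2ccccc2)cc1` gives 4300 nM. Compound 3 `CC[C@H](C)[C@H](N)CN(C(=O)[C@@H]1C[C@H]1c1cccc(C#N)c1)c1ccc(-c2ccccc2)cc1` differs from compound 2 in one place: cyano in place of fluoro on an aromatic carbon. For the measured compounds named here, the single measured step, a 7.7-fold lower number from compound 1 to compound 2 (0.89 log units; beyond the scatter), concerns another change and does not bear directly on cyano in place of fluoro; no step with a cyano group is known here, so only a small to modest move is anticipated. Compound 3 is expected to give 900 nM, within 300 nM to 3000 nM. The expected step is a 1.6-fold higher number from compound 2 to compound 3 (0.21 log units; within the scatter).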

Compound 3, half-maximal effective concentration: 1600 nM
Beside the measured number, compound 3's estimate is 1.8-fold (0.25 log units) below it; the range from low to high includes it.
By their numbers in this assay, from the lowest: compound 2; then compound 3; then compound 1.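

In this assay cyano in place of fluoro on this aromatic carbon gives a 2.9-fold higher number from compound 2 to compound 3 (0.46 log units; beyond the scatter) and so the position responds to the group it carries, with fluoro ahead of cyano in this pair. The 3-cyanophenyl group still compares well with 4-chlorophenyl, at a 2.7-fold lower number from compound 1 to compound 3 (0.43 log units; beyond the scatter) and so the lower number of compound 2 is not confined to fluoro. Nothing at hand explains either step. Still open, as far as these compounds go, is how an amine or a methoxy group on the same aromatic carbon would read, and whether chloro would behave like fluoro there.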